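Cyano to Hydroxyethyl Amide: Cell Toxicity Expectation

The source may hold more compounds than are shown below. What is called first, only, known or untested is meant among the compounds shown, and "the series" means these compounds.

Compound 1, `CCCCc1cc2c(=O)c(C#N)c[nH]c2cc1OCCOc1ccccc1`, was tested in an ADME assay on J774 cells (Mus musculus) for cytotoxicity; a higher number here means that more compound is needed for the effect, a lower number that less compound is needed. In this assay compound 1 reaches only the limit of the measurement, > 20000 nM, so no number is known for it. A second compound, compound 2, `COC(=O)c1c[nH]c2ccc(C(C)C)cc2c1=O`, carries a related core with different substituents. In this assay compound 2 also stops at the limit, > 20000 nM. Both readings therefore share the same mark: the limit of > 20000 nM in this assay, at which 2 of the 2 values shown sit. Within the range tested, neither compound shows the effect.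

Compound 3, `CCCCc1cc2c(=O)c(C(=O)NCCO)c[nH]c2cc1OCCOc1ccccc1`, has not been measured. It differs from compound 1 in a single place: (2-hydroxyethyl)carbamoyl in place of cyano on an aromatic carbon. Within the data shown here, no step between two measured compounds is available to anchor this change, so the expectation rests on the limits alone. Because compound 1 sits at > 20000 nM, the step that the limit leaves unreadable from compound 1 to compound 3 is expected to be none beyond the usual scatter. Compound 3 is therefore expected to give about 30000 nM, with a range from 15000 nM to 80000 nM, most likely again as a limit rather than a number.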

Compound 3, half-maximal effective concentration: > 20000 nM
Compound 3: no number, only a limit; the forecaster's own chance of this, stated with the estimate: 80%; the middle value is on the limit's open side.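

Among these compounds, compound 1 and compound 3 both give only a limit in this assay, not a number, so no step between them can be read. The three compounds shown share one mark: the limit of > 20000 nM in this assay, at which 3 of the 3 values shown sit.

The compounds shown leave open what concentration, if any, would harm these cells, and whether (2-hydroxyethyl)carbamoyl in place of cyano changes it.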